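Aryl change on the amide of compound 2

The compounds below may be only part of what the source reports. "The series", "measured", "known", "first", "only" and "open" are said of these compounds alone.

In a functional assay on HT-29 cells (Homo sapiens) for cytotoxicity, read by MTT assay, with a stated time of 72 h (on this read-out lower numbers stand for stronger inhibition and higher numbers for weaker inhibition), compound 1 (`COc1ccc(NC(=O)CN2CCN(c3nnc(Cc4ccncc4)c4ccccc34)CC2)cc1OC`) gives 40100 nM, compound 2 (`O=C(CN1CCN(c2nnc(Cc3ccccc3)c3ccccc23)CC1)Nc1c(F)cccc1F`) gives 19700 nM and compound 3 (`Cc1ccc(NC(=O)CN2CCN(c3nnc(Cc4ccncc4)c4ccccc34)CC2)c(C)c1`) gives 1930 nM. Compound 2 therefore holds the second highest of the three numbers, with the gaps to both others beyond the scatter.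

Compound 4 (`Cc1ccc(F)cc1NC(=O)CN1CCN(c2nnc(Cc3ccccc3)c3ccccc23)CC1`) carries 5-fluoro-2-methylphenyl in place of 2,6-difluorophenyl on an amide-type nitrogen.

One measured step changes this same place: a 21-fold lower number from compound 1 to compound 3 (1.32 log units; beyond the scatter). This large step brings in 2,4-dimethylphenyl in place of 3,4-dimethoxyphenyl. Neither group involved in it is the group leaving or entering here, so it shows only that this place can move the number a long way. For the measured compounds named here, a methyl on the phenyl is the one feature the entering group shares with it.

A modest move to a lower number in this assay is expected, well short of that step. The expected change is a 2.5-fold lower number from compound 2 to compound 4 (0.39 log units; beyond the scatter). Compound 4 is estimated at 8000 nM, with an expected range of 2000 nM to 30000 nM.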

Compound 4, half-maximal inhibitory concentration: 171000 nM
Compound 4: middle estimate off by 21-fold (1.33 log units), on the low side; measured number above the stated range.
By their numbers in this assay, from the lowest: compound 3; then compound 2; then compound 1; then compound 4.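

In this assay the exchange of 2,6-difluorophenyl for 5-fluoro-2-methylphenyl gives an 8.7-fold higher number from compound 2 to compound 4 (0.94 log units; beyond the scatter), so this amide aryl position can also move the number upward, and a change confined to the substituents on the phenyl is enough to do so. A methyl on the phenyl therefore does not go with a lower number in every case: compound 3 points that way with a 21-fold lower number from compound 1 to compound 3 (1.32 log units; beyond the scatter), while compound 4 goes against it, and these two steps stand on different cores. No measurement in hand bears on the reason for the rise.

As far as these compounds go, whether 5-fluoro-2-methylphenyl would give a similar step on the core of compound 1 remains open. Also open, from the compounds shown here alone, is how this position would respond to a non-aryl group such as a morpholine, or to a phenyl carrying a carboxylic acid.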